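The compounds below may be only part of what the source reports. "The series", "measured", "known", "first", "only" and "open" are said of these compounds alone.

Of the compounds shown here, three sharing one core have been tested in a functional assay on PC-3 cells (Homo sapiens) for antiproliferative activity, read by MTT assay, with a stated time of 72 h; a lower number here means a stronger inhibitor, a higher number a weaker inhibitor. Here, compound 1 `O=C(N/N=C/c1ccc(Br)cc1)Nc1ccc(Oc2ccnc3[nH]ccc23)c(F)c1`, which carries bromo, gives 920 nM. Compound 3 `O=C(N/N=C/c1ccc(O)cc1)Nc1ccc(Oc2ccnc3[nH]ccc23)c(F)c1`, which carries hydroxy, gives 2780 nM, and compound 2 `N#Cc1ccc(/C=N/NC(=O)Nc2ccc(Oc3ccnc4[nH]ccc34)c(F)c2)cc1`, which carries cyano, gives 9030 nM. Compound 2 thus has the highest number of the three and is the weakest inhibitor so far, with both gaps beyond the scatter.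

Compound 4 `COc1ccc(/C=N/NC(=O)Nc2ccc(Oc3ccnc4[nH]ccc34)c(F)c2)cc1` has not yet been measured. It differs from compound 2 at a single place: methoxy in place of cyano on an aromatic carbon. In words, methoxy stands in place of cyano on an aromatic carbon, para to a large group.

Two measured steps involve the cyano group. Going from bromo to cyano gives a 9.8-fold higher number from compound 1 to compound 2 (0.99 log units; beyond the scatter), and replacing cyano with hydroxy gives a 3.2-fold lower number from compound 2 to compound 3 (0.51 log units; beyond the scatter). Both are modest, and both show cyano with the higher number. The remaining step, a 3.0-fold higher number from compound 1 to compound 3 (0.48 log units; beyond the scatter), shows that the two groups other than cyano also differ from each other, so the size of the next step is uncertain. Within the data shown here, no methoxy compound has been measured yet. A modest drop in this assay is therefore expected, close in size to the hydroxy step. The expected change is a 3.2-fold lower number from compound 2 to compound 4 (0.51 log units; beyond the scatter). For compound 4 the estimated value is 2800 nM, with an expected range of 900 nM to 8000 nM.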

Compound 4, half-maximal inhibitory concentration: 6730 nM
Compound 4: the middle estimate sits 2.4-fold (0.38 log units) below what was measured; low and high end bracket the measured number.
By their numbers in this assay, from the lowest: compound 1; then compound 3; then compounds 4 and 2 (each within the scatter of the next).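

In this assay, putting methoxy in place of cyano gives a 1.3-fold lower number from compound 2 to compound 4 (0.13 log units; within the scatter), so these two groups cannot be told apart at this position, and cyano no longer stands out from every other group tested there. Adding just a methyl to the oxygen of the hydroxy group gives a 2.4-fold higher number from compound 3 to compound 4 (0.38 log units; beyond the scatter), showing that even this small change at the same position can be read in the assay, while putting methoxy in place of bromo gives a 7.3-fold higher number from compound 1 to compound 4 (0.86 log units; beyond the scatter), which leaves compound 1 the strongest inhibitor of the four. Nothing available here explains why these groups differ in this way.

The compounds shown leave open where chloro, an amine or a carboxylic acid would fall at this position on the ring, and whether a longer chain on the oxygen, such as ethoxy, would carry on the change seen from hydroxy to methoxy. They also leave open whether the same order of groups would hold if another part of the shared core were changed.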